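Hexyl Ester of a Malonamide: Expected Gain in Potency

The compounds below may be only part of what the source reports. "The series", "measured", "known", "first", "only" and "open" are said of these compounds alone.

Compound 1 `CC(C)c1cccc(C(C)C)c1NC(=O)CC(=O)O` carries a hydroxy end on its shared core. In an assay on microsomes from intestine for inhibition of acyl-CoA:cholesterol acyltransferase (Oryctolagus cuniculus) (on this read-out higher numbers stand for weaker inhibition and lower numbers for stronger inhibition), compound 1 gives only a limit, > 5000 nM, not a number. Where this stands is shown by the limit of > 5000 nM in this assay, at which 1 of the 3 values shown sits. Two further compounds of the same core have real values: compound 2 `CC(C)c1cccc(C(C)C)c1NC(=O)CC(=O)Oc1c(-c2ccccc2)cccc1-c1ccccc1` gives 67 nM in this assay, and compound 3 `COc1cc(OC)c(OC(=O)CC(=O)Nc2c(C(C)C)cccc2C(C)C)c(OC)c1` gives 320 nM. Compound 4 `CCCCCCOC(=O)CC(=O)Nc1c(C(C)C)cccc1C(C)C` has not yet been measured; it differs from compound 1 by hexyl in place of hydrogen on an oxygen next to a carbonyl group. Because compound 2 reaches 67 nM and compound 3 reaches 320 nM, a large step toward stronger inhibition is expected, an at least 16-fold lower number from compound 1 to compound 4 (1.22 log units; beyond the scatter). Compound 4 is therefore estimated at 300 nM, within 80 nM to 1500 nM.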

Compound 4, half-maximal inhibitory concentration: 810 nM
Compound 4: middle estimate off by 2.7-fold (0.43 log units), on the low side; the measured number falls inside the stated range.
By their numbers in this assay, from the lowest: compound 2; then compound 3; then compound 4. At a limit, above all of these: compound 1.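

In this assay, hexyl in place of hydrogen on this oxygen brings an at least 6.1-fold lower number from compound 1 to compound 4 (0.79 log units; beyond the scatter) and so shows that a plain chain with no ring can give a clear gain here, where compounds 2 and 3 both carry rings. For compound 1 the reading > 5000 nM is a limit, not a number. The full size of the step stays unknown because its starting point is a limit: the limit of > 5000 nM in this assay, at which 1 of the 4 values shown sits.

Still open, on these data alone, is how a shorter chain such as ethyl, a longer chain such as decyl or a branched chain would read at this oxygen.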